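The compounds below may be only part of what the source reports. "The series", "measured", "known", "first", "only" and "open" are said of these compounds alone.

Working notes on the series, read in an ADME assay on microsomes from liver (Mus musculus) for metabolic stability, read by LC-MS, with a stated time of 10 min; a higher number here means that more of the compound is left, a lower number that less of the compound is left. Compound 1 (`c1cnc2c(c1)CCC[C@@H]2N(CC1CC1)C[C@H]1Cc2c(cccc2N2CCNCC2)CN1`) gives 88.3%. Compound 2 (`CN(C[C@H]1Cc2c(cccc2N2CCN(C3CC3)CC2)CN1)[C@H]1CCCc2cccnc21`) gives 7% and compound 3 (`CC(C)N1CCN(c2cccc3c2C[C@H](CN(C)[C@H]2CCCc4cccnc42)NC3)CC1`) gives 15.1%. These two lie within the scatter of each other, and both stand far under compound 1. Compound 4 (`CN1CCN(c2cccc3c2C[C@H](CN(C)[C@H]2CCCc4cccnc42)NC3)CC1`) carries one change from compound 2, methyl in place of cyclopropyl on an amine nitrogen in a ring. Among the compounds with values here, the only measured step at this place is a number 8.1 percentage points higher from compound 2 to compound 3 (within the scatter), with isopropyl entering, and it stays within the scatter. Within the data shown here, compound 1 differs from compound 2 in more than one place and gives no clean step. No shift beyond the scatter is expected in this assay. The expected step is a number 5 percentage points higher from compound 2 to compound 4 (within the scatter). For compound 4 the estimate is 12%, with an expected range from 4% to 30%.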

Compound 4, percent of the compound remaining: 17%
Beside the measured number, compound 4's estimate is 5 percentage points below it; the measured number falls inside the stated range.
By their numbers in this assay, from the lowest: compounds 2, 3 and 4 (each within the scatter of the next); then compound 1.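

In this assay, methyl on this amine nitrogen in a ring gives a number 10 percentage points higher from compound 2 to compound 4 (within the scatter) and a number 1.9 percentage points higher from compound 3 to compound 4 (within the scatter). Cyclopropyl, isopropyl and methyl therefore read alike at this place, and going from 3 heavy atoms to 1 leaves the number within the scatter. Nothing measured here explains this flat reading.

Going by these compounds, whether an acetyl group or a hydroxyethyl chain on this nitrogen would move the number stays open. On these data alone, compound 1 differs from these compounds in more than one place, so what sets its number apart also stays open.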